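Fluorophenyl for methylphenyl on the ring nitrogen

This account rests on a few compounds, and the source may have more. Where it says the series, first, only, none or still open, it means among the compounds named here.

Compound 3 `Cc1cccc(-n2cc(-c3ccc(NS(=O)(=O)c4c[nH]c(=O)[nH]c4=O)cc3)nn2)c1` has been measured in a functional assay on OVCAR-3 cells (Homo sapiens) for antiproliferative activity, read by MTT assay, with a stated time of 24 h (on this read-out higher numbers stand for weaker inhibition and lower numbers for stronger inhibition), where compound 3 gives 7490 nM. Among the two plain numbers shown this is the highest, with compound 1 `Cc1ccccc1-n1cc(-c2ccccc2NS(=O)(=O)c2c[nH]c(=O)[nH]c2=O)nn1` nearest: compound 1 gives 6550 nM, a gap within the scatter, so no order is read between the two. Compound 2 `O=c1[nH]cc(S(=O)(=O)Nc2ccccc2-c2cn(-c3cccc(F)c3)nn2)c(=O)[nH]1` reaches only a limit in this assay, > 20000 nM. This is the limit of > 20000 nM in this assay, at which 1 of the 3 values shown sits.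

The untested compound 4 `O=c1[nH]cc(S(=O)(=O)Nc2ccc(-c3cn(-c4ccc(F)cc4)nn3)cc2)c(=O)[nH]1` differs from compound 3 in one place: 4-fluorophenyl in place of 3-methylphenyl on an aromatic nitrogen. For the measured compounds named here, the one measured step of a similar kind is an at least 3.0-fold higher number from compound 1 to compound 2 (0.48 log units; beyond the scatter), a methylphenyl exchanged for a fluorophenyl on the same aromatic nitrogen, though the substituent positions within the phenyl differ from those here. That step went towards weaker inhibition and was at least modest. On this basis the change from compound 3 to compound 4 is expected to lie in the same direction, a modest rise in the number in this assay, with a real chance of running into the limit. Compound 4 is expected at 15000 nM, within a range of 6000 nM to 40000 nM. The expected step is a 2.0-fold higher number from compound 3 to compound 4 (0.30 log units; within the scatter).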

Compound 4, half-maximal inhibitory concentration: > 20000 nM
Compound 4: a limit, no number; the forecaster's own chance of this, stated with the estimate: 35%; middle value at least 1.3-fold (0.12 log units) from the limit.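

The exchange of a methylphenyl for a fluorophenyl on the aromatic nitrogen now appears twice in this assay: an at least 2.6-fold higher number from compound 3 to compound 4 (0.42 log units; beyond the scatter) goes the same way as an at least 3.0-fold higher number from compound 1 to compound 2 (0.48 log units; beyond the scatter), so the direction is no longer carried by a single pair. Compound 2 and compound 4 both end at a limit rather than a number, with 3-fluorophenyl in one and 4-fluorophenyl in the other: the limit of > 20000 nM in this assay, at which 2 of the 4 values shown sit. Among the compounds shown, both methylphenyl compounds give plain numbers and both fluorophenyl compounds reach the limit, with no compound against this pattern.

On these data alone, the true size of either step stays open, as does any order between the two fluorophenyl compounds. Also open, as far as these compounds go, is whether a plain phenyl, a chlorophenyl or a methoxyphenyl on the same aromatic nitrogen would give a plain number.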